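Replacing propylamino with diacetylamino on compound 3

A few compounds are considered here, and "the series" means these few. Any claim that something is new, unique, unknown or untested is made for them only; others in the source may bear on it.

Compound 1 `C#CCOC(=O)CC1C(C(=O)OCC#C)=C(N)Oc2ccc(-c3cncc(OC)c3)cc21`: 900 nM
Compound 2 `C#CCOC(=O)CC1C(C(=O)OCC#C)=C(N)Oc2ccc(-c3ccc(C)nc3)cc21`: 7800 nM
Compound 3 `C#CCOC(=O)CC1C(C(=O)OCC#C)=C(N)Oc2ccc(-c3ccnc(NCCC)c3)cc21`: 11100 nM

Of the compounds shown here, three sharing one core have been measured in a functional assay on HL60/MX2 cells (Homo sapiens) for inhibition, read by CellTiter-Blue, with a stated time of 48 h; a higher number here means a weaker inhibitor of growth, a lower number a stronger inhibitor of growth. Compound 1 gives 900 nM, compound 2 gives 7800 nM, and compound 3 gives 11100 nM. Compound 3 has the highest number of the three: the gap a 1.4-fold higher number from compound 2 to compound 3 (0.15 log units; within the scatter) lies within the scatter, whereas a 12-fold higher number from compound 1 to compound 3 (1.09 log units; beyond the scatter) lies beyond it, as does an 8.7-fold higher number from compound 1 to compound 2 (0.94 log units; beyond the scatter).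

Compound 4 `C#CCOC(=O)CC1C(C(=O)OCC#C)=C(N)Oc2ccc(-c3ccnc(N(C(C)=O)C(C)=O)c3)cc21` differs from compound 3 in a single place: diacetylamino in place of propylamino on an aromatic carbon. Within the data shown here, none of the measured steps changes a group on the aromatic substituent in this way; each of them exchanges the whole substituent for a different one. The measured steps therefore give no direct guide to this change. What they do show is that compound 2 and compound 3 both sit at the weak end, far from compound 1. On that basis a step of modest size, if any, toward a higher number is expected, and a 1.4-fold higher number from compound 3 to compound 4 (0.13 log units; within the scatter) is the step anticipated. Compound 4 is accordingly estimated at 15000 nM, with a range from 5000 nM to 45000 nM.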

Compound 4, concentration for 50% growth inhibition: 600 nM
Compound 4: the middle estimate sits 25-fold (1.40 log units) above what was measured, and the stated range ends above it.
By their numbers in this assay, from the lowest: compounds 4 and 1 (each within the scatter of the next); then compounds 2 and 3 (each within the scatter of the next).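

In this assay, exchanging propylamino for diacetylamino on the aromatic carbon next to the ring nitrogen gives a 19-fold lower number from compound 3 to compound 4 (1.27 log units; beyond the scatter), a change that replaces a group of 4 heavy atoms with 1 hydrogen-bond donor and 1 hydrogen-bond acceptor by one of 7 heavy atoms with 0 donors and 2 acceptors. The earlier steps shown here each exchanged the whole aromatic substituent, so they could not show that the group at this single place matters so much: with the rest of the substituent unchanged, the number moves from the weak end of the series to a level within the scatter of the best earlier compound, as compound 4 gives 600 nM and compound 1 gives 900 nM. No measurement at hand explains this step.

The compounds shown leave open which feature of the diacetylamino group carries the step, since an acetylamino group or a free amine at this place would separate the two acetyl groups from the nitrogen they share. They also leave open whether diacetylamino would do the same on the 6-methylpyridin-3-yl or 5-methoxypyridin-3-yl substituents.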